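The compounds below may be only part of what the source reports. "The series", "measured", "known", "first", "only" and "open" are said of these compounds alone.

Compound 1 `Cn1c(-c2ccccc2)nc2c(NC3CCCCC3)ncnc21` and compound 2 `CCn1c(-c2ccccc2)nc2c(NC3CCOC3)ncnc21` share one core and differ from each other in two places, so no single change links them. In an assay on CHO cells for displacement of a labelled ligand from adenosine receptor A3 (Homo sapiens), read by scintillation counting, with a stated time of 3 h (a lower number here means a stronger inhibitor, a higher number a weaker inhibitor), compound 1 gives 2370 nM, and in this assay compound 2 gives 1660 nM. These two numbers lie within the usual scatter of repeated measurements of each other, and the data give no ground for telling the two compounds apart. Compound 3 `Cn1c(-c2ccccc2)nc2c(NC3CCOC3)ncnc21` is compound 2 with one change: hydrogen in place of methyl on a saturated chain carbon bound to an aromatic nitrogen. Among the measured compounds shown here, no measured pair shows what such a change does here; the two measured compounds differ in more than this one place. A change of this size, methyl to hydrogen, is expected to move the number little, if at all beyond the scatter. The expected step of a 1.1-fold higher number from compound 2 to compound 3 (0.04 log units; within the scatter) is therefore small. For compound 3 the estimate in this assay is 1800 nM, with a range from 700 nM to 4500 nM.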

Compound 3, inhibition constant: 6260 nM
For compound 3 the middle estimate is 3.5-fold (0.54 log units) below the measured one; the measured number lies above the stated range.
By their numbers in this assay, from the lowest: compounds 2 and 1 (each within the scatter of the next); then compound 3.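

In this assay, cutting the ethyl on the aromatic nitrogen back to methyl gives a 3.8-fold higher number from compound 2 to compound 3 (0.58 log units; beyond the scatter), so this place responds to the loss of a single carbon, and by more than the scatter. The oxolan-3-yl on a nitrogen on an aromatic ring can now also be read on its own, since putting it in place of cyclohexyl gives a 2.6-fold higher number from compound 1 to compound 3 (0.42 log units; beyond the scatter). Nothing in the data explains either step.

Each of these readings rests on one pair of compounds, so neither shows whether the same change would do the same on another part of the series. Going by these compounds, whether a longer chain such as propyl in place of the ethyl would lower the number further remains open, as does the effect of an amine in place of the oxolan-3-yl.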